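Nitro for trifluoromethyl in a series near its limit

This account rests on a few compounds, and the source may have more. Where it says the series, first, only, none or still open, it means among the compounds named here.

Values in a functional assay on SW982 cells (Homo sapiens) for inhibition, read by MTT assay, with a stated time of 72 h; on this read-out lower numbers stand for stronger inhibition and higher numbers for weaker inhibition:
- compound 1 `COc1cc(OC)c(OC)cc1/C=C/C(=O)c1ccccc1` gives > 150000 nM (a limit)
- compound 2 `COc1cc(OC)c(OC)cc1/C=C/C(=O)c1ccc(Cl)c([N+](=O)[O-])c1` gives 20600 nM
- compound 3 `COc1cc(OC)c(OC)cc1/C=C/C(=O)c1cccc(C(F)(F)F)c1` gives > 150000 nM (a limit)

Compound 3 gives > 150000 nM in this assay and this is a limit, not a number. This is the limit of > 150000 nM in this assay, at which 2 of the 3 values shown sit, and compound 3 therefore has no measured number of its own.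

Compound 4 `COc1cc(OC)c(OC)cc1/C=C/C(=O)c1cccc([N+](=O)[O-])c1` follows from compound 3 with nitro in place of trifluoromethyl on an aromatic carbon, meta to a large group (nitro in place of trifluoromethyl on an aromatic carbon). Among the compounds with values here, the one measured step that touches compound 3 is a step that the two limits leave unreadable from compound 1 to compound 3 and it offers no size to carry over. Within the data shown here, the only numeric guide is compound 2, which also carries a nitro group and gives 20600 nM in this assay, though it holds a chlorine that compound 4 lacks.

A change toward stronger inhibition is therefore expected, with a real chance that the limit persists. The expected change is an at least 2.5-fold lower number from compound 3 to compound 4 (0.39 log units; beyond the scatter) (uncertain in size). For compound 4 the estimate is 60000 nM (expected range 15000 nM to 150000 nM).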

Compound 4, half-maximal inhibitory concentration: 101000 nM
Beside the measured number, compound 4's estimate is 1.7-fold (0.23 log units) below it, and the stated range covers the measured number.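

In this assay, nitro at this position on an aromatic carbon gives a measured number, whereas hydrogen and trifluoromethyl there gave only limits (an at least 1.4-fold lower number from compound 3 to compound 4 (0.17 log units; that floor lies within the scatter); an at least 1.4-fold lower number from compound 1 to compound 4 (0.17 log units; that floor lies within the scatter)). Hydrogen in place of chloro on the nitro compound weakens inhibition beyond the scatter (a 4.9-fold higher number from compound 2 to compound 4 (0.69 log units; beyond the scatter)), so nitro alone does not account for the number of compound 2. Both steps into compound 4 are only floors that stay within the scatter, because the values they start from are limits: the limit of > 150000 nM in this assay, at which 2 of the 4 values shown sit.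

The true size of those two steps and of the step from hydrogen to trifluoromethyl cannot be read. From the compounds shown here alone, how a nitrile or an amine at this position, or chloro without nitro, would compare remains open.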